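Pyridin-3-yl to 5-Methyl-1H-imidazol-4-yl: a Cytotoxicity Step

The source may report more compounds than this note shows. Statements on the series, on what has been measured and on what is new or still open speak of the compounds shown alone.

Compound 1 `Cc1c(/C=N/NC(=O)c2ccncc2)no[n+]1[O-]` gives in an ADME assay on J774.1 cells (Mus musculus) for cytotoxicity, read by MTT assay, with a stated time of 48 h (on this read-out higher numbers stand for weaker inhibition and lower numbers for stronger inhibition), only a limit, > 400000 nM.
Compound 2 `Cc1c(/C=N/NC(=O)c2cccnc2)no[n+]1[O-]` gives in this assay only a limit, > 400000 nM.

Compound 2 therefore stands at a limit in this assay, with no number of its own. Among the measured compounds shown here, the one measured step, a step that the two limits leave unreadable from compound 1 to compound 2, cannot be read because of the limit of > 400000 nM in this assay, at which 2 of the 2 values shown sit, and it offers no size to lean on. Compound 3 `Cc1[nH]cnc1C(=O)N/N=C/c1no[n+]([O-])c1C` differs from compound 2 in one place: 5-methyl-1H-imidazol-4-yl in place of pyridin-3-yl on a carbonyl carbon. For the measured compounds named here, no measured step bears on this change beyond the fact that both known compounds sit at the same limit, as the limit of > 400000 nM in this assay, at which 2 of the 2 values shown sit, shows. Compound 3 is therefore expected to stay near that limit, with an estimated value of 400000 nM in this assay, between 150000 nM and 1000000 nM. The expected step from compound 2 is a number no higher from compound 2 to compound 3 (the limit leaves the size open), which is estimated to be no change beyond the scatter.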

Compound 3, half-maximal inhibitory concentration: > 400000 nM
Compound 3: only a limit was reported (the forecaster's own chance of this, stated with the estimate: 80%); the middle value sits exactly at the limit.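

Compound 3, like compound 1 and compound 2, gives only a limit in this assay, so no step among these three compounds can be read: the limit of > 400000 nM in this assay, at which 3 of the 3 values shown sit. The compounds shown leave open whether pyridin-4-yl, pyridin-3-yl and 5-methyl-1H-imidazol-4-yl differ at all in this assay.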